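A few compounds are considered here, and "the series" means these few. Any claim that something is new, unique, unknown or untested is made for them only; others in the source may bear on it.

Measured compounds in an assay on CHO-K1 cells for displacement of a labelled ligand from adenosine receptor A1 (Homo sapiens), read by scintillation counting, with a stated time of 60 min; a lower number here means a stronger inhibitor, a higher number a weaker inhibitor:
Compound 1 `CCOc1cc(/C=N/Nc2nc(N)c3ncn([C@@H]4O[C@H](CO)[C@@H](O)[C@H]4O)c3n2)ccc1O`: 6940 nM
Compound 2 `COc1cc(/C=N/Nc2nc(N)c3ncn([C@@H]4O[C@H](CO)[C@@H](O)[C@H]4O)c3n2)cc(OC)c1OC`: a limit only, > 10000 nM
Compound 3 `Nc1nc(N/N=C/c2ccc(C(F)(F)F)cc2C(F)(F)F)nc2c1ncn2[C@@H]1O[C@H](CO)[C@@H](O)[C@H]1O`: a limit only, > 10000 nM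

For the measured compounds named here, compound 1 stands as the only member of the set for which this assay returns a number. Compound 2 and compound 3 both sit at the limit of > 10000 nM in this assay, at which 2 of the 3 values shown sit, so no order among the three can be drawn from the values shown, and nothing tells whether compound 1 differs from either of the other two beyond the usual scatter.

Compound 4 `CN(C)c1ccc(/C=N/Nc2nc(N)c3ncn([C@@H]4O[C@H](CO)[C@@H](O)[C@H]4O)c3n2)cc1` has not yet been measured. Relative to compound 1 it carries 4-(dimethylamino)phenyl in place of 3-ethoxy-4-hydroxyphenyl on a carbon with a double bond to nitrogen. Going by the values given here, no pair of measured compounds differs in one place, so there is no measured step to lean on; the set shows only that the single number came with the 3-ethoxy-4-hydroxyphenyl group, while the two other aryl groups gave a limit. On that basis the step from compound 1 to compound 4 is expected to be small and in the weakening direction, a 1.3-fold higher number from compound 1 to compound 4 (0.11 log units; within the scatter), with a real chance that this assay again reports only a limit. Compound 4 is therefore estimated at 9000 nM, with a range from 2500 nM to 25000 nM.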

Compound 4, inhibition constant: > 10000 nM
Compound 4 ended at the assay's limit (the forecaster's own chance of this, stated with the estimate: 45%); at least 1.1-fold (0.04 log units) between middle value and limit.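

In this assay compound 4 gives > 10000 nM, which is a limit of the assay and not a number. This provides the first step in the series at a single place, on a carbon with a double bond to nitrogen: 4-(dimethylamino)phenyl in place of 3-ethoxy-4-hydroxyphenyl gives an at least 1.4-fold higher number from compound 1 to compound 4 (0.15 log units; that floor lies within the scatter), so a real loss from this change is neither shown nor ruled out. The 3-ethoxy-4-hydroxyphenyl group of compound 1 remains the only aryl group here that returns a number, and the set now stands mostly at the limit: the limit of > 10000 nM in this assay, at which 3 of the 4 values shown sit.

As far as these compounds go, the distance of compound 2, compound 3 and compound 4 beyond the limit stays unknown, so the steps among them cannot be read and no order among them can be given. Also open, from the compounds shown here alone, is whether the number for compound 1 goes with the hydroxyl group, the ethoxy group or the two together, a question that a plain phenyl, a phenyl with a lone hydroxyl or lone ethoxy group, or a phenyl with a longer alkoxy chain could help settle.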